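Cyclopentyl for Ethyl on the Ring Amine Nitrogen

The source may report more compounds than this note shows. Statements on the series, on what has been measured and on what is new or still open speak of the compounds shown alone.

Compound 1 `Cc1ccc(S(=O)(=O)N2C=CNC(=O)[C@H]2CC(=O)N[C@@H]2CCc3ccccc32)cc1`: 94.7 nM
Compound 2 `CCN1CC[C@H](NC(=O)C[C@@H]2C(=O)NC=CN2S(=O)(=O)c2ccc(C)cc2)C(C)(C)C1`: 0.63 nM

Among the compounds with values here, in an in vitro functional assay on cells for antagonist activity at B1 bradykinin receptor (Homo sapiens), read by luminescence and calcium flux, with a stated time of 2 h (on this read-out lower numbers stand for stronger inhibition and higher numbers for weaker inhibition), compound 2 holds the lower of the two numbers, and the only measured step, a 150-fold lower number from compound 1 to compound 2 (2.18 log units; beyond the scatter), sets it apart from compound 1. Compound 3 `Cc1ccc(S(=O)(=O)N2C=CNC(=O)[C@H]2CC(=O)N[C@H]2CCN(C3CCCC3)CC2(C)C)cc1` differs from compound 2 by cyclopentyl in place of ethyl on an amine nitrogen in a ring, on an amine nitrogen in a ring. Within the data shown here, that step replaced a different group on the amide-type nitrogen, so no measured step bears on this change. For compound 3 a step within the scatter is therefore expected, a 1.3-fold higher number from compound 2 to compound 3 (0.10 log units; within the scatter). Compound 3 is estimated at 0.8 nM, in a range from 0.2 nM to 3.5 nM.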

Compound 3, half-maximal inhibitory concentration: 0.247 nM
Estimate against measurement, compound 3: 3.2-fold (0.51 log units) above, and the stated range covers the measured number.
By their numbers in this assay, from the lowest: compound 3; then compound 2; then compound 1.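

In this assay, the change on the ring amine nitrogen gives a 2.6-fold lower number from compound 2 to compound 3 (0.41 log units; beyond the scatter) and this small gain lies beyond the scatter. It is the first step shown at this position, and it shows that cyclopentyl, with its five carbon atoms, is accepted there in place of ethyl without loss. No measurement offered here explains the step.

Going by these compounds, it remains open whether methyl or cyclohexyl on this nitrogen would extend the trend. A tetrahydropyranyl ring, which carries an oxygen atom, is likewise untested in these compounds.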